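The source may report more compounds than this note shows. Statements on the series, on what has been measured and on what is new or still open speak of the compounds shown alone.

Two close relatives of a shared core have been measured in a functional assay on HUVEC cells (Homo sapiens) for antiproliferative activity, read by MTT assay, with a stated time of 48 h; on this read-out higher numbers stand for weaker inhibition and lower numbers for stronger inhibition. Compound 1, with the structure `Cc1ccc(NC(=O)Nc2nnc(Sc3ncnc4scc(-c5ccncc5)c34)s2)cc1Cl`, gives 23200 nM in this assay. Compound 2, with the structure `Cc1ccc(NC(=O)Nc2nnc(Sc3ncnc4scc(-c5ccncc5)c34)s2)cc1`, gives 19300 nM in this assay. Among the compounds with values here, the only step measured so far, a 1.2-fold lower number from compound 1 to compound 2 (0.08 log units; within the scatter), removes a chloro from the same six-membered ring that carries the methyl. On the numbers shown, compound 2 stands lowest of the two, with compound 1 as its only neighbour, and the two lie within the scatter of each other, so no order can be read from them.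

Compound 3, with the structure `O=C(Nc1ccc(Cl)cc1)Nc1nnc(Sc2ncnc3scc(-c4ccncc4)c23)s1`, differs from compound 2 by chloro in place of methyl on an aromatic carbon. Within the data shown here, the one step that touches a chloro on this ring, a 1.2-fold lower number from compound 1 to compound 2 (0.08 log units; within the scatter), stayed within the scatter, and so the expected step in this assay, a 1.0-fold higher number from compound 2 to compound 3 (0.02 log units; within the scatter), is none beyond the scatter. Compound 3 is therefore estimated at 20000 nM in this assay, within a range from 8000 nM to 50000 nM.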

Compound 3, half-maximal inhibitory concentration: 11600 nM
Compound 3: the middle estimate sits 1.7-fold (0.24 log units) above what was measured; measured number inside the range.
By their numbers in this assay, from the lowest: compounds 3, 2 and 1 (each within the scatter of the next).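

Exchanging the methyl for a chloro, para to a large group on the six-membered aromatic ring of carbon only, gives a 1.7-fold lower number from compound 2 to compound 3 (0.22 log units; within the scatter) in this assay, so replacing the group at this position, and not only removing a chloro from the ring, has so far produced no step beyond the scatter. The wider change to 4-chlorophenyl from 3-chloro-4-methylphenyl gives a 2.0-fold lower number from compound 1 to compound 3 (0.30 log units; within the scatter) and also stays within the scatter, which leaves all three compounds without a readable order. Nothing available explains these small differences.

Going by these compounds, whether a different kind of group at this position, such as an amine, a methoxy or a carboxylic acid, would move the number beyond the scatter remains open. Within the data shown here, every step so far also lies on this one ring, so the effect of changes elsewhere on the shared core is unknown.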